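The compounds below may be only part of what the source reports. "The series", "measured", "known", "first", "only" and "open" are said of these compounds alone.

Measured so far:
Compound 1 `Cc1cn([C@@H]2C[C@H](O)[C@@H](CNC(=O)Nc3ccc(Br)cc3)O2)c(=O)[nH]c1=O` gives > 50000 nM in an ADME assay on MRC5 cells (Homo sapiens) for cytotoxicity (on this read-out lower numbers stand for higher toxicity in this test and higher numbers for lower toxicity in this test), which is an assay limit rather than a number.
Compound 2 `Cc1cn([C@@H]2C[C@H](O)[C@@H](CNC(=O)Nc3ccccc3COc3ccccc3)O2)c(=O)[nH]c1=O` gives > 50000 nM in this assay, again a limit.
Compound 3 `Cc1cn([C@@H]2C[C@H](O)[C@@H](CNC(=O)Nc3ccc(OC4CCOCC4)cc3)O2)c(=O)[nH]c1=O` gives > 50000 nM in this assay, also a limit.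

Going by the values given here, compound 3 therefore stands where all of its companions stand: every value so far sits at the limit of > 50000 nM in this assay, at which 3 of the 3 values shown sit, compound 3 among them. Nothing separates compound 3 from compound 1 or compound 2 on the numbers shown.

Compound 4 `Cc1cn([C@@H]2C[C@H](O)[C@@H](CNC(=O)Nc3ccc(-c4ccc(C(F)(F)F)nc4)cc3)O2)c(=O)[nH]c1=O` has not yet been measured. It differs from compound 3 in one place: 6-(trifluoromethyl)pyridin-3-yl in place of (oxan-4-yl)oxy on an aromatic carbon. Among the compounds with values here, the only measured step that touches the same position is a step that the two limits leave unreadable from compound 1 to compound 3, and that step cannot be read, as both ends are limits. Within the data shown here, there is thus no measured step that points to a change in either direction beyond the scatter in this assay.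

Compound 4 is consequently expected to remain at or near the same limit, with an estimate of 60000 nM and a range from 15000 nM to 200000 nM. The step from compound 3 to compound 4 is expected to be a step that the limit leaves unreadable from compound 3 to compound 4, with a real chance that only a limit is reported.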

Compound 4, half-maximal cytotoxic concentration: > 50000 nM
Compound 4 gave a limit, no number; the forecaster's own chance of this, stated with the estimate: 65%; the middle value does not contradict the limit.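

No step from compound 1 or compound 3 to compound 4 can be read in this assay, since both ends of each step are limits: the limit of > 50000 nM in this assay, at which 4 of the 4 values shown sit.

The compounds shown leave open how far each lies beyond that limit, and whether exchanging the group on the aromatic carbon changes the read-out at all.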